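The source may hold more compounds than are shown below. What is called first, only, known or untested is meant among the compounds shown, and "the series" means these compounds.

Compound 1 `CCc1cc(C(=O)n2cccc2)cc(C#N)c1O`: 83%
Compound 2 `N#Cc1cc(C(=O)N2CC=CC2)cc(I)c1O`: 79%
Compound 3 `CCCc1cc(C(=O)N2CC=CC2)cc(C(F)(F)F)c1O`: 49%

Of the compounds shown here, three have so far been measured in an assay on isolated protein for inhibition of solute carrier family 22 member 12 (Homo sapiens), tested at 3 uM; on this read-out higher numbers stand for more inhibition at the one concentration tested (going by the name of the read-out) and lower numbers for less inhibition. Among these numbers compound 2 stands second highest. Its nearest neighbour is compound 1, whose value lies within the usual scatter of that of compound 2, so the two cannot be ordered; its furthest is compound 3, whose value lies beyond the scatter below that of compound 2. The unmeasured compound 4 `N#Cc1cc(C(=O)N2CC=CC2)cc(Cl)c1O` differs from compound 2 in a single place: chloro in place of iodo on an aromatic carbon. For the measured compounds named here, no pair of measured compounds differs in one place only, so no measured step is available for this change, and the three measured values are the whole basis for an expectation. The step from compound 2 to compound 4 is expected to be a modest loss, a number 14 percentage points lower from compound 2 to compound 4 (beyond the scatter), one that may well fall within the scatter. Compound 4 is therefore expected to give 65% in this assay, with a range from 40% to 85%.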

Compound 4, a percentage reported as inhibition, at one concentration (the size of the read-out at that concentration, not a potency): 66%
Compound 4: middle estimate off by 1 percentage points, on the low side; low and high end bracket the measured number.
By their numbers in this assay, from the lowest: compound 3; then compound 4; then compounds 2 and 1 (each within the scatter of the next).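

In this assay, for the compounds shown here, the change of iodo to chloro on this aromatic carbon, ortho to a hydroxy group, gives the first step that can be read at a single place: a number 13 percentage points lower from compound 2 to compound 4 (beyond the scatter). This shows that the read-out responds to which of these two halogens stands at this position, although compound 4 still gives 66% at the one concentration tested, so iodo is not required for measurable inhibition. Nothing available here accounts for the size or direction of this step.

Going by these compounds, whether bromo, methyl or an amine at this position would give a number close to that of iodo or of chloro remains open. On these data alone, it is also open whether the same halogen change would give a similar step with another group in place of the group of 7 heavy atoms.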